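Substituent swap at the saturated ring carbon of the pyrazoline series

The compounds below may be only part of what the source reports. "The series", "measured", "known", "first", "only" and "open" are said of these compounds alone.

Compound 2 `Cc1cc(O)c(C2=NN(c3ccc(S(N)(=O)=O)cc3)C(/C=C/c3ccccc3)C2)cc1Cl` carries a 2-phenylethenyl group on a saturated ring carbon of the shared core. In a functional assay on SK-MEL-5 cells (Homo sapiens) for antiproliferative activity, with a stated time of 48 h (on this read-out lower numbers stand for stronger inhibition of growth and higher numbers for weaker inhibition of growth), compound 2 gives 16400 nM, the highest of the two numbers recorded; compound 1 `Cc1cc(O)c(C2=NN(c3ccc(S(N)(=O)=O)cc3)C(c3ccccc3Cl)C2)cc1Cl` gives 12300 nM, and the step of a 1.3-fold higher number from compound 1 to compound 2 (0.12 log units; within the scatter) stays within the scatter. Compound 3 `COc1ccc(C2CC(c3cc(Cl)c(C)cc3O)=NN2c2ccc(S(N)(=O)=O)cc2)cc1OC` is the next member: 3,4-dimethoxyphenyl in place of 2-phenylethenyl on a saturated ring carbon, the position being on a saturated ring carbon of a five-membered non-aromatic ring with 2 nitrogen, next to the ring nitrogen. Within the data shown here, the only measured step at this position is a 1.3-fold higher number from compound 1 to compound 2 (0.12 log units; within the scatter), where exchanging one aryl-type group for another moved the read-out by less than the scatter. On that basis a step of a 1.2-fold lower number from compound 2 to compound 3 (0.07 log units; within the scatter) is expected, in no direction beyond the scatter. Compound 3 is therefore estimated at 14000 nM, with a range from 6000 nM to 35000 nM in this assay.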

Compound 3, concentration for total growth inhibition: 15200 nM
Compound 3: the middle estimate sits 1.1-fold (0.04 log units) below what was measured, and the stated range covers the measured number.
By their numbers in this assay, from the lowest: compounds 1, 3 and 2 (each within the scatter of the next).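

In this assay, the position on a saturated ring carbon of the shared core now holds a third group, and both new steps lie within the scatter (a 1.1-fold lower number from compound 2 to compound 3 (0.03 log units; within the scatter); a 1.2-fold higher number from compound 1 to compound 3 (0.09 log units; within the scatter)). Compared with 2-phenylethenyl, 3,4-dimethoxyphenyl has 2 hydrogen-bond acceptors rather than 0 and no double bond outside aromatic rings, yet this exchange also leaves the read-out within the scatter. No measurement shown accounts for this result.

On these data alone, all three groups at this position contain a six-membered aromatic ring, so it remains open whether a primary amine, a carboxylic acid or a plain butyl chain would give a step beyond the scatter. As far as these compounds go, it also remains open whether this insensitivity to the exchange extends to other cell lines.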